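The compounds below may be only part of what the source reports. "The series", "measured", "known", "first", "only" and "open" are said of these compounds alone.

Compound 2 `COc1ccc2c(c1)CCC(NC(=O)Nc1cccc3cnccc13)C2Cc1ccc(C(F)(F)F)cc1` has the lowest of the two numbers measured in a functional assay on HEK293 cells for antagonist activity at transient receptor potential cation channel subfamily V member 1 (Homo sapiens), read by FLIPR (a lower number here means a stronger inhibitor, a higher number a weaker inhibitor), where compound 2 gives 2 nM. For the measured compounds named here, the only other measured compound is compound 1 `O=C(Nc1cccc2cnccc12)NC1CCc2cc(F)ccc2C1Cc1ccoc1`, which in this assay gives 83 nM; compound 1 differs from compound 2 in two places at once, so the gap between their two values cannot be assigned to either change on its own.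

Compound 3 `O=C(Nc1cccc2cnccc12)NC1CCc2cc(F)ccc2C1Cc1ccc(C(F)(F)F)cc1` is the next compound to be measured. It differs from compound 2 in one place: fluoro in place of methoxy on an aromatic carbon. The trifluoromethyl-bearing side chain of compound 2 is kept unchanged in compound 3.

Going by the values given here, there is no measured step that isolates this exchange. The expectation for compound 3 is a step of a 2.0-fold higher number from compound 2 to compound 3 (0.30 log units; within the scatter), small and most likely within the usual scatter, since compound 1 with a fluoro on the same ring already gives 83 nM and shows that a fluoro there is compatible with a low number. For compound 3 the estimated value in this assay is 4 nM, with a range from 1.5 nM to 12 nM.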

Compound 3, half-maximal inhibitory concentration: 10 nM
For compound 3 the middle estimate is 2.5-fold (0.40 log units) below the measured one; the measured number falls inside the stated range.
By their numbers in this assay, from the lowest: compound 2; then compound 3; then compound 1.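

In this assay, the exchange of methoxy for fluoro on the aromatic carbon, meta to a fused ring and para to a fused ring, now stands on its own, with the 4-(trifluoromethyl)phenyl side chain held fixed: it gives a 5.0-fold higher number from compound 2 to compound 3 (0.70 log units; beyond the scatter), so the group at this position does affect the number. For the compounds shown here, compound 3 also isolates the side chain for the first time, since with fluoro held on the ring, 4-(trifluoromethyl)phenyl in place of furan-3-yl gives an 8.3-fold lower number from compound 1 to compound 3 (0.92 log units; beyond the scatter), and so each of the two changes that separate compound 1 from compound 2 has now been seen alone, each with a step beyond the scatter. Nothing available here accounts for either step.

Among the compounds shown, this aromatic carbon carries only methoxy or fluoro, so it remains open where a chloro, a hydroxyl or an ethoxy group would fall. On these data alone, it is also open whether the methoxy-to-fluoro step would keep its size with furan-3-yl as the side chain, and how a different side chain, such as cyclohexyl or a pyridine, would compare.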